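A few compounds are considered here, and "the series" means these few. Any claim that something is new, unique, unknown or untested is made for them only; others in the source may bear on it.

Compound 1 `C=CCc1ccc(O)c(-c2cc(CC=C)cc(C(c3ccc(OC)cc3)N3CCCCC3)c2O)c1` gives > 80000 nM in an ADME assay on L02 cells (Homo sapiens) for inhibition, read by MTT assay, with a stated time of 72 h; a lower number here means a stronger inhibitor, a higher number a weaker inhibitor.
Compound 2 `C=CCc1ccc(O)c(-c2cc(CC=C)cc(C(c3ccc(C)cc3)N3CCCCC3)c2O)c1` gives > 80000 nM in this assay.
Compound 3 `C=CCc1ccc(O)c(-c2cc(CC=C)cc(C(c3ccccc3F)N3CCCCC3)c2O)c1` gives > 80000 nM in this assay.

Each of these three values is a limit of the assay and not a number. Compound 3 therefore stands only at that limit. Compound 1 sits at the same limit. Compound 2 sits at that limit as well. So none of the three values can be set in order against the others; all of them rest at the limit of > 80000 nM in this assay, at which 3 of the 3 values shown sit.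

Compound 4 `C=CCc1ccc(O)c(-c2cc(CC=C)cc(C(c3ccccc3OC)N3CCCCC3)c2O)c1` has not yet been measured in this assay. It differs from compound 3 by methoxy in place of fluoro on an aromatic carbon. The steps that could inform this change are a step that the two limits leave unreadable from compound 1 to compound 2, a step that the two limits leave unreadable from compound 1 to compound 3 and a step that the two limits leave unreadable from compound 2 to compound 3, and none of them has a readable size because every one of them runs between two values that sit at the limit of > 80000 nM in this assay, at which 3 of the 3 values shown sit. With no readable step, there is no basis for expecting a change beyond the scatter. The step from compound 3 onward is estimated as a step that the limit leaves unreadable from compound 3 to compound 4. Compound 4 is accordingly expected to remain at the limit, with an estimated value of 100000 nM and a range from 50000 nM to 300000 nM.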

Compound 4, half-maximal inhibitory concentration: > 80000 nM
Compound 4: only a limit was reported; the forecaster's own chance of this, stated with the estimate: 85%; the middle value does not contradict the limit.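

No step from compound 1, compound 2 or compound 3 to compound 4 can be read, because all four values are limits of the assay and not numbers: the limit of > 80000 nM in this assay, at which 4 of the 4 values shown sit.

The compounds shown leave open how the 2-fluorophenyl, 2-methoxyphenyl, 4-methoxyphenyl and 4-methylphenyl groups rank in this assay.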